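The compounds below may be only part of what the source reports. "The series", "measured", "known", "first", "only" and "open" are said of these compounds alone.

Of the compounds shown here, two sharing one core have been tested in an ADME assay on HEK293 cells (Homo sapiens) for cytotoxicity, read by resazurin assay, with a stated time of 48 h; on this read-out lower numbers stand for higher toxicity in this test and higher numbers for lower toxicity in this test. Compound 1 `O=S(=O)(Nc1ccc(-c2nc3ccccc3o2)cc1)c1cccc(F)c1` gives > 100000 nM in this assay, and that figure is a limit of the assay rather than a number. Within the data shown here, compound 2 `O=S(=O)(Nc1ccc2oc(-c3ccccc3)nc2c1)c1cccc(F)c1` gives 68000 nM in this assay, which is the only true number in hand. The remaining result sits at the limit of > 100000 nM in this assay, at which 1 of the 2 values shown sits. Compound 3 `COc1ccc(S(=O)(=O)Nc2ccc3oc(-c4ccccc4)nc3c2)cc1` has not yet been measured. It differs from compound 2 in one place: 4-methoxyphenyl in place of 3-fluorophenyl on a sulfonyl sulfur. Among the measured compounds shown here, no pair of measured compounds shows what this exchange does, so there is nothing to calibrate it against. The step from compound 2 to compound 3 is expected to stay within the scatter of repeated measurements, with no clear direction, so the estimated change is a 1.0-fold higher number from compound 2 to compound 3 (0.01 log units; within the scatter). Compound 3 is therefore expected to give about 70000 nM in this assay, most likely between 30000 nM and 150000 nM.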

Compound 3, half-maximal cytotoxic concentration: 91000 nM
Compound 3: the middle estimate sits 1.3-fold (0.11 log units) below what was measured; the measured number falls inside the stated range.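

This position now has its first measured exchange in this assay, and it reads a 1.3-fold higher number from compound 2 to compound 3 (0.13 log units; within the scatter). Swapping 3-fluorophenyl for 4-methoxyphenyl on a sulfonyl sulfur therefore shows no clear change in toxicity in this test, even though the entering group carries a hydrogen-bond acceptor and the leaving group carries none. Compound 1 stands at a limit of the assay, not at a number: the limit of > 100000 nM in this assay, at which 1 of the 3 values shown sits.

Among these compounds, with only this one exchange, it remains open whether the fluorine and the methoxy group each have no clear effect or whether two separate effects happen to offset each other, which plain phenyl on the sulfur could help to separate. Also open, as far as these compounds go, is what a group of a different kind, such as an amine or a carboxylic acid, would do at this position in this assay.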